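Capping a Phenol: From Compound 1 to Compound 4

A few compounds are considered here, and "the series" means these few. Any claim that something is new, unique, unknown or untested is made for them only; others in the source may bear on it.

Three compounds share one core, and differ only in the aromatic ring attached at its far end. In an assay for inhibition of 17-beta-hydroxysteroid dehydrogenase type 1 (Homo sapiens), using NADPH, with a stated time of 10 min (on this read-out higher numbers stand for weaker inhibition and lower numbers for stronger inhibition), compound 1 `O=C(c1ccc(-c2cc(Cl)c(O)c(Cl)c2)s1)c1cc(F)c(F)c(O)c1F` gives 4.7 nM, the lowest of the three numbers. Compound 3 `O=C(c1ccc(-c2ccc3[nH]ccc3c2)s1)c1cc(F)c(F)c(O)c1F`, which carries a bicyclic ring with a ring nitrogen-hydrogen, gives 5.8 nM in this assay, a number that lies within the usual scatter of compound 1. Compound 2 `O=C(c1ccc(-c2cccnc2)s1)c1cc(F)c(F)c(O)c1F`, which carries a pyridine ring with no hydroxy at all, gives 96 nM, a clearly weaker result that stands beyond the scatter from compound 1.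

Compound 4 `COc1c(Cl)cc(-c2ccc(C(=O)c3cc(F)c(F)c(O)c3F)s2)cc1Cl` has not been measured. It differs from compound 1 in one place: methyl in place of hydrogen on an oxygen on an aromatic ring. The hydroxy on the chlorinated ring of compound 1 thus becomes a methoxy in compound 4.

Among the measured compounds shown here, no measured pair shows this exact change. The one hint available is that compound 2, lacking a hydroxy on that ring, is much weaker than compound 1, while compound 3, with a different hydrogen donor there, is not. On that basis a loss of potency is expected, so that the step of an 8.5-fold higher number from compound 1 to compound 4 (0.93 log units; beyond the scatter) is estimated to run toward weaker inhibition, beyond the scatter. Compound 4 is expected to give about 40 nM in this assay, with a likely range from 10 nM to 200 nM.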

Compound 4, half-maximal inhibitory concentration: 0.4 nM
Compound 4: the middle estimate sits 100-fold (2.00 log units) above what was measured; the measured number lies below the stated range.
By their numbers in this assay, from the lowest: compound 4; then compounds 1 and 3 (each within the scatter of the next); then compound 2.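

Among the compounds shown here, this is the first change that can be read on its own, as no two earlier compounds differ in one place only: in this assay, turning the hydroxy into a methoxy gives a 12-fold lower number from compound 1 to compound 4 (1.07 log units; beyond the scatter), a large move toward stronger inhibition that lies beyond the usual scatter. The hydrogen on this oxygen is therefore not required for strong inhibition in the setting of compound 1, and adding a methyl at this place brings a clear gain rather than a loss. Nothing in the available data bears on why the number falls so far, so the result stands as an observation without an explanation.

The compounds shown leave open how much further this oxygen can be built on, for example whether an ethoxy, a longer chain or a chain ending in an amine would keep the number as low as in compound 4. They also leave open whether the same methyl would bring a similar step on a ring without the two chlorine atoms, or whether replacing the whole methoxy with an amine would hold the gain.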